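Swapping Bromine for Ethyl on the Aryl Urea

The compounds below may be only part of what the source reports. "The series", "measured", "known", "first", "only" and "open" are said of these compounds alone.

Of the compounds shown here, three sharing one core have been measured in a functional assay on the whole organism for inhibition, with Mus musculus as the target, with a stated time of 1 h, at a dose of 100 mg/kg by the intraperitoneal route; a lower number here means less inhibition, a higher number more inhibition at the dose given (going by the name of the read-out). Compound 1 `Cc1nc2ccccc2c(=O)n1NC(=O)Nc1ccc(I)cc1` gives 53%, compound 2 `Cc1nc2ccccc2c(=O)n1NC(=O)Nc1ccc(Br)cc1` gives 51%, and compound 3 `Cc1nc2ccccc2c(=O)n1NC(=O)Nc1ccc(F)cc1` gives 45%. Compound 2 holds the middle of these three numbers, and all three lie within the scatter of one another, so none can be called stronger or weaker than the others.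

Compound 4 `CCc1ccc(NC(=O)Nn2c(C)nc3ccccc3c2=O)cc1` differs from compound 2 in one place: ethyl in place of bromo on an aromatic carbon.

The steps measured so far all exchange one halogen for another on the same aromatic carbon: a number 2 percentage points lower from compound 1 to compound 2 (within the scatter), a number 6 percentage points lower from compound 2 to compound 3 (within the scatter) and a number 8 percentage points lower from compound 1 to compound 3 (within the scatter). None of them moves the read-out beyond the scatter. Going by the values given here, no measured step replaces a halogen with an ethyl group, so the new change has no direct precedent here. Given how little the halogen swaps moved this assay, the expected step is a number 3 percentage points lower from compound 2 to compound 4 (within the scatter), that is, none beyond the scatter. Compound 4 is therefore estimated at 48%, with a range from 35% to 60%.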

Compound 4, a percentage reported as inhibition, in the whole organism at one dose (the size of the read-out at that dose, not a potency): 53%
Compound 4: middle estimate off by 5 percentage points, on the low side; the measured number falls inside the stated range.
By their numbers in this assay, from the lowest: compounds 3, 2, 1 and 4 (each within the scatter of the next).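

Ethyl carries no halogen, yet this aromatic carbon takes it without a clear shift in this assay: the swap for bromo gives a number 2 percentage points higher from compound 2 to compound 4 (within the scatter), the swap for fluoro gives a number 8 percentage points higher from compound 3 to compound 4 (within the scatter), and the swap for iodo gives no change at the digits printed from compound 1 to compound 4 (within the scatter). A halogen at this carbon is therefore not required to keep the read-out in this range, at least among these four compounds, which all lie within the scatter of one another. Nothing at hand explains why the numbers stay so close.

Still open, on these data alone, is whether an amine, a carboxylic acid or a longer chain such as butyl at this carbon would move the read-out beyond the scatter. Each number also gives only the size of the effect at one dose, so compounds that look alike here could still differ at other doses.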